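Furan to Phenyl on the Amide of Compound 1

The source may hold more compounds than are shown below. What is called first, only, known or untested is meant among the compounds shown, and "the series" means these compounds.

Measured so far:
compound 1 `COc1ccc(-c2cnc(NC(=O)c3ccco3)n2C)cc1` — > 100000 nM
compound 2 `Cc1ccc(C(=O)Nc2ncc(-c3ccccc3)o2)cc1` — 26000 nM
compound 3 `Cn1c(-c2ccccc2)cnc1NC(=O)c1ccc(Cl)cc1` — > 100000 nM

In a toxicity assay on THP-1 cells (Homo sapiens) for inhibition (on this read-out lower numbers stand for higher toxicity in this test and higher numbers for lower toxicity in this test), compound 1 gives only a limit, > 100000 nM, and not a number. Compound 3 likewise gives only a limit in this assay, > 100000 nM. Going by the values given here, compound 2 is the one measured compound with a number in this assay, 26000 nM. Compound 1 thus stands at the limit of > 100000 nM in this assay, at which 2 of the 3 values shown sit, and nothing finer can be said of its place.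

The unmeasured compound 4 `COc1ccc(-c2cnc(NC(=O)c3ccccc3)n2C)cc1` differs from compound 1 in one place: phenyl in place of furan-2-yl on a carbonyl carbon. Among the compounds with values here, no step between two measured compounds shows what this change does in this assay. Since compound 1 sits at a limit, and compound 3, which also carries a phenyl on its carbonyl carbon, sits at a limit too, the expected step from compound 1 to compound 4 is a number no higher from compound 1 to compound 4 (the limit leaves the size open), that is, none beyond the scatter. Compound 4 is therefore expected to give about 100000 nM, with a range from 30000 nM to 300000 nM, and most likely again only a limit.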

Compound 4, half-maximal cytotoxic concentration: > 100000 nM
Compound 4 ended at the assay's limit; the forecaster's own chance of this, stated with the estimate: 65%; the middle value sits exactly at the limit.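

In this assay, compound 1 and compound 4 both give only a limit and not a number, and the step between them cannot be read. The compounds shown leave open whether phenyl in place of furan-2-yl on the carbonyl carbon changes this read-out at all.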